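The source may report more compounds than this note shows. Statements on the series, on what has been measured and on what is new or still open speak of the compounds shown alone.

Measured so far:
Compound 1, `CC#CC(CC(=O)O)c1ccc(OC2CCCC2)cc1`, in an assay on CHO cells for inhibition of Free fatty acid receptor 1 (Homo sapiens) (a lower number here means a stronger inhibitor, a higher number a weaker inhibitor), gives 312 nM.
Compound 2, `CC#CC(c1ccc(OCc2ccccc2)cc1)C1OC(=O)NC1=O`, in this assay gives 4400 nM.

Compound 1 stands at the lowest of the two numbers; compound 2 sits at a clearly higher number, beyond the usual scatter. Compound 3, `CC#CC(CC(=O)O)c1ccc(Oc2ncc(Br)cn2)cc1`, differs from compound 1 in one place: 5-bromopyrimidin-2-yl in place of cyclopentyl on an oxygen on an aromatic ring. Within the data shown here, no measured pair shows what such an exchange does, so the expectation rests on compound 1 alone. The expected step, a 1.2-fold lower number from compound 1 to compound 3 (0.10 log units; within the scatter), lies within the scatter. Compound 3 is therefore estimated at 250 nM, with a likely range from 80 nM to 800 nM.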

Compound 3, half-maximal inhibitory concentration: 433 nM
Beside the measured number, compound 3's estimate is 1.7-fold (0.24 log units) below it, and the stated range covers the measured number.
By their numbers in this assay, from the lowest: compounds 1 and 3 (each within the scatter of the next); then compound 2.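

With a 1.4-fold higher number from compound 1 to compound 3 (0.14 log units; within the scatter) in this assay, cyclopentyl and 5-bromopyrimidin-2-yl cannot be told apart on this oxygen on an aromatic ring. A five-membered carbon ring without hydrogen-bond acceptors and a six-membered aromatic ring with two of them thus give comparable numbers at this position. No measurement here explains this result. Whether the bromine contributes remains open, since the same ring carrying hydrogen in its place is not among these compounds. Also open, from the compounds shown here alone, is how a phenyl ring or a longer carbon chain on this oxygen would compare.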